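The source may hold more compounds than are shown below. What is called first, only, known or untested is meant among the compounds shown, and "the series" means these compounds.

Three compounds sharing one core have been examined in an ADME assay on MT4 cells (Homo sapiens) for cytotoxicity; a lower number here means that less compound is tolerated, a higher number that more compound is tolerated. Compound 1 `O=C(CSc1snnc1-c1ccc(F)cc1F)Nc1ccccc1F` gives 148000 nM. Compound 3 `O=C(CSc1snnc1-c1ccc(F)cc1F)Nc1ccccc1[N+](=O)[O-]` gives 165000 nM, and the step of a 1.1-fold higher number from compound 1 to compound 3 (0.05 log units; within the scatter) follows from exchanging nitro for fluoro on an aromatic carbon. Compound 2 `Cc1ccc(NC(=O)CSc2snnc2-c2ccc(F)cc2F)c(Br)c1` reaches only the limit of this assay, reported as > 273000 nM; its standing on the numbers is therefore a floor, not a value, as noted in the limit of > 273000 nM in this assay, at which 1 of the 3 values shown sits. The step of an at least 1.8-fold higher number from compound 1 to compound 2 (0.26 log units; that floor lies within the scatter) and the step of an at least 1.6-fold lower number from compound 2 to compound 3 (0.21 log units; that floor lies within the scatter) both rest on that floor.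

Compound 4 `COc1ccc(-c2nnsc2SCC(=O)Nc2ccc(C)cc2Br)cc1` is the next compound to be measured. The change from compound 2 is 4-methoxyphenyl in place of 2,4-difluorophenyl on an aromatic carbon. Going by the values given here, every measured step so far alters the aryl group on the amide-type nitrogen, none touches the aryl on the five-membered aromatic ring, so no measured step bears directly on this change. The three measured values lie within the scatter of one another, which gives no reason to expect a step beyond the scatter in this assay. The account therefore expects compound 4 to sit near the floor of compound 2, with an estimated step of an at least 1.0-fold lower number from compound 2 to compound 4 (0.03 log units; that floor lies within the scatter). For compound 4 the estimate in this assay is 250000 nM, with a range from 110000 nM to 550000 nM.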

Compound 4, half-maximal cytotoxic concentration: 249000 nM
Estimate against measurement, compound 4: 1.0-fold (0.00 log units) above; low and high end bracket the measured number.
By their numbers in this assay, from the lowest: compounds 1, 3 and 4 (each within the scatter of the next). At a limit, above all of these: compound 2.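

Going by these compounds alone, compound 4 gives the first measured change to the aryl group on the five-membered aromatic ring, where every earlier step altered the aryl group on the amide-type nitrogen. In this assay, putting 4-methoxyphenyl in place of 2,4-difluorophenyl at this position gives an at least 1.0-fold lower number from compound 2 to compound 4 (0.03 log units; that floor lies within the scatter), so this exchange, which removes both fluorines and brings in an oxygen and a hydrogen-bond acceptor, shows no step beyond the scatter as far as it can be read. That reading has a clear bound, as compound 2 has a limit and not a number: the limit of > 273000 nM in this assay, at which 1 of the 4 values shown sits.

On these data alone, the true distance between these two compounds therefore stays unknown, and it is also open whether the same exchange would give a comparable step with 2-fluorophenyl or 2-nitrophenyl on the amide-type nitrogen. Also open, as far as these compounds go, is how a phenyl carrying an amine or a carboxylic acid would read at this position in this assay, and whether any group here would move the number beyond the scatter.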